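Sulfonamide nitrogen methylation in the shared core series

The source may hold more compounds than are shown below. What is called first, only, known or untested is meant among the compounds shown, and "the series" means these compounds.

Compound 1, `Cn1ccc2ccc(-c3cc(Nc4ccccc4S(N)(=O)=O)cc4nccnc34)cc21`: 37600 nM in an assay on lysate for inhibition of 6-phosphofructo-2-kinase/fructose-2,6-bisphosphatase 3 (Homo sapiens), with stated times of 0.5 min and 45 min; a lower number here means a stronger inhibitor, a higher number a weaker inhibitor
Compound 2, `CNS(=O)(=O)c1ccccc1Nc1cc(-c2ccc3ccn(C)c3c2)c2nccnc2c1`: > 100000 nM in this assay, which is a limit of the assay and not a number

In this assay compound 1 gives 37600 nM. For compound 2 the figure > 100000 nM is a limit of the assay rather than a measured number. Among the measured compounds shown here, the only step measured so far runs an at least 2.6-fold higher number from compound 1 to compound 2 (0.42 log units; beyond the scatter) and ends at the limit of > 100000 nM in this assay, at which 1 of the 2 values shown sits. Compound 2 thus stands at the weak end of what this assay can report, with only a limit known.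

Compound 3 `CN(C)S(=O)(=O)c1ccccc1Nc1cc(-c2ccc3ccn(C)c3c2)c2nccnc2c1` repeats the same kind of change on compound 2: methyl in place of hydrogen on a sulfonamide nitrogen. For the measured compounds named here, the one measured step that bears on it, an at least 2.6-fold higher number from compound 1 to compound 2 (0.42 log units; beyond the scatter), went toward a weaker inhibitor. The step that the limit leaves unreadable from compound 2 to compound 3 is therefore expected in the same direction or flat, with compound 3 most likely again reported only as a limit. The estimate for compound 3 in this assay is 150000 nM, with a range from 60000 nM to 500000 nM.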

Compound 3, half-maximal inhibitory concentration: 7670 nM
For compound 3 the middle estimate is 20-fold (1.29 log units) above the measured one; measured number below the stated range.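

At this position, the same change does not keep one direction: methyl in place of hydrogen on the sulfonamide nitrogen gave an at least 2.6-fold higher number from compound 1 to compound 2 (0.42 log units; beyond the scatter), whereas repeating it gave an at least 13-fold lower number from compound 2 to compound 3 (1.11 log units; beyond the scatter) in this assay. The value for compound 2 is a limit of the assay and not a number: the limit of > 100000 nM in this assay, at which 1 of the 3 values shown sits. Dimethylamino in place of amino on the sulfonyl sulfur gives a 4.9-fold lower number from compound 1 to compound 3 (0.69 log units; beyond the scatter), so compound 3 is the strongest inhibitor of the three, and the effect of the change depends on what the sulfonamide nitrogen already carries.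

The compounds shown do not explain why the monomethyl compound 2 falls out of line between the other two. On these data alone, whether the gain is specific to dimethylamino remains open, and diethylamino or a pyrrolidine ring on the sulfonyl sulfur would test it.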